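A few compounds are considered here, and "the series" means these few. Any claim that something is new, unique, unknown or untested is made for them only; others in the source may bear on it.

Within the data shown here, in a functional assay on the whole organism (strain Swiss albino) for inhibition, with Mus musculus as the target, in the writhing test, with stated times of 60 min and 15 min, at a dose of 100 mg/kg by the oral route (on this read-out lower numbers stand for less inhibition and higher numbers for more inhibition at the one dose given (going by the name of the read-out)), compound 1 `COc1cc2c(cc1OC)C(CC(=O)NC(C)(C)C)CC2` gives 41.8%, the lower of the two numbers known, while compound 2 `CCCCCCNC(=O)CC1CCc2cc(OC)c(OC)cc21` gives 82.2%. Among the measured compounds shown here, the one measured step, a number 40.4 percentage points higher from compound 1 to compound 2 (beyond the scatter), came from hexyl in place of tert-butyl on an amide-type nitrogen. Compound 3 `COc1cc2c(cc1OC)C(CC(=O)NCCO)CC2` alters the same position differently: 2-hydroxyethyl in place of tert-butyl on an amide-type nitrogen. For the measured compounds named here, only that single step bears on this change, and it concerns a different entering group, so the direction for compound 3 is uncertain. The step is expected to be a number 8.2 percentage points higher from compound 1 to compound 3 (within the scatter) in this assay. Compound 3 is accordingly estimated at 50%, within 25% to 78%.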

Compound 3, a percentage reported as inhibition, in the whole organism at one dose (the size of the read-out at that dose, not a potency): 29.8%
Estimate against measurement, compound 3: 20.2 percentage points above; the range from low to high includes it.
By their numbers in this assay, from the lowest: compound 3; then compound 1; then compound 2.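

Changing the group on the amide-type nitrogen can move the read-out in this assay either way: 2-hydroxyethyl in place of tert-butyl gives a number 12 percentage points lower from compound 1 to compound 3 (beyond the scatter) and so falls, unlike the hexyl change. Hydroxy in place of butyl on a saturated chain carbon, two bonds along the chain from an amide-type nitrogen, gives a number 52.4 percentage points lower from compound 2 to compound 3 (beyond the scatter) and marks the widest separation among the three compounds. No evidence is available to explain these differences.

As far as these compounds go, whether a methoxyethyl or an aminoethyl group would follow compound 3 remains open. So does whether a chain longer than hexyl would exceed compound 2.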